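Swapping the ring on the amide nitrogen: chloro to nitro

A few compounds are considered here, and "the series" means these few. Any claim that something is new, unique, unknown or untested is made for them only; others in the source may bear on it.

Compound 2 `O=C(Nc1ccc(Cl)cc1)c1ccc(/N=N\c2c[nH]c3ccccc23)cc1` is the weaker of the two measured compounds in a functional assay on P388 cells (Mus musculus) for inhibition, read by MTT assay, with a stated time of 72 h (a lower number here means a stronger inhibitor, a higher number a weaker inhibitor), where compound 2 gives 80000 nM. For the measured compounds named here, compound 1 `Cc1ccc(NC(=O)c2ccc(/N=N\c3c[nH]c4ccccc34)cc2)cc1` gives 300 nM, and the single measured step, a 270-fold higher number from compound 1 to compound 2 (2.43 log units; beyond the scatter), shows how much one small change on the ring attached to the amide nitrogen can matter. Compound 3 `O=C(Nc1cccc([N+](=O)[O-])c1)c1ccc(/N=N\c2c[nH]c3ccccc23)cc1` differs from compound 2 by 3-nitrophenyl in place of 4-chlorophenyl on an amide-type nitrogen. Going by the values given here, no measured step covers this change, so the direction is uncertain; the estimate for compound 3 is 20000 nM, between 2000 nM and 200000 nM, a step of a 4.0-fold lower number from compound 2 to compound 3 (0.60 log units; beyond the scatter).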

Compound 3, half-maximal inhibitory concentration: 51900 nM
For compound 3 the middle estimate is 2.6-fold (0.41 log units) below the measured one; the range from low to high includes it.
By their numbers in this assay, from the lowest: compound 1; then compounds 3 and 2 (each within the scatter of the next).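

In this assay 3-nitrophenyl on the amide-type nitrogen gives a 1.5-fold lower number from compound 2 to compound 3 (0.19 log units; within the scatter) and so cannot be told apart from 4-chlorophenyl here. Set against the 4-methylphenyl of compound 1, the same group gives a 170-fold higher number from compound 1 to compound 3 (2.24 log units; beyond the scatter) and so compound 1 stays alone as the strongest of the three, with two quite different rings both far weaker. On these data alone, whether the methyl itself matters stays open, as does what a plain phenyl, an amine or a carboxylic acid would do in this place. No measured evidence explains why these rings differ.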